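This account rests on a few compounds, and the source may have more. Where it says the series, first, only, none or still open, it means among the compounds named here.

Measured in a functional assay on A549 cells (Homo sapiens) for cytotoxicity, read by MTT assay; a higher number here means a weaker inhibitor, a lower number a stronger inhibitor: compound 1 `CC(C)[C@H](NC(=S)NCc1ccccc1)c1nc2ccccc2[nH]1` gives 56100 nM; compound 2 `CC(C)[C@H](NC(=S)Nc1ccccc1)c1nc2ccccc2[nH]1` gives 5200 nM.

Among the compounds with values here, compound 2 carries the lower of the two numbers, and the only step between them, an 11-fold lower number from compound 1 to compound 2 (1.03 log units; beyond the scatter), turns on the phenyl in place of benzyl on the amide-type nitrogen. Compound 3 `CC(C)[C@@H](NC(=S)Nc1ccccc1)c1nc2ccccc2[nH]1` keeps that phenyl; (the two compounds have the same atoms and bonds and differ only in configuration as drawn: 1 of 1 stereo elements differ; a stereocentre at a saturated chain carbon is drawn S in compound 2 and R in compound 3). Within the data shown here, no measured step touches configuration, so nothing in this assay fixes the direction of the change. The step is expected to be a 1.5-fold higher number from compound 2 to compound 3 (0.19 log units; within the scatter), wide on both sides. Compound 3 is therefore estimated at 8000 nM, range 2000 nM to 40000 nM.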

Compound 3, half-maximal inhibitory concentration: 31500 nM
The estimate for compound 3 lay 3.9-fold (0.60 log units) below the measured number; low and high end bracket the measured number.
By their numbers in this assay, from the lowest: compound 2; then compounds 3 and 1 (each within the scatter of the next).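

Reversing the stereocentre at the saturated chain carbon from S to R gives a 6.1-fold higher number from compound 2 to compound 3 (0.78 log units; beyond the scatter) in this assay. Configuration therefore joins the phenyl in place of benzyl as a second place in the series where a single change moves the number beyond the scatter, with S giving the lower number in this phenyl pair. The step can be assigned to the stereocentre alone because nothing else separates the pair: the fact that compounds 2 and 3 differ only in the configuration as drawn.

From the compounds shown here alone, whether S also gives the lower number with benzyl on that nitrogen remains open. Also open, going by these compounds, is how a carboxylic acid on the phenyl ring, or a longer chain at the stereocentre, would behave.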